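A few compounds are considered here, and "the series" means these few. Any claim that something is new, unique, unknown or untested is made for them only; others in the source may bear on it.

Compound 1 `Cc1nn(C)c(Oc2cccc(F)c2F)c1/C=N\CCCCCCOc1cc2oc(=O)cc(C)c2cc1Cl`: 22800 nM
Compound 2 `Cc1nn(C)c(Oc2cccc(Br)c2)c1/C=N\CCCCCCOc1cc2oc(=O)cc(C)c2cc1Cl`: 5080 nM

Both numbers come from a functional assay on SMMC-7721 cells (Homo sapiens) for antiproliferative activity, read by MTT assay, with a stated time of 72 h; on this read-out lower numbers stand for stronger inhibition and higher numbers for weaker inhibition. Compound 2 has the lowest number of the two; its nearest neighbour is compound 1, and the step from compound 1 to compound 2, a 4.5-fold lower number from compound 1 to compound 2 (0.65 log units; beyond the scatter), lies beyond the scatter. Compound 3 `Cc1ccccc1Oc1c(/C=N\CCCCCCOc2cc3oc(=O)cc(C)c3cc2Cl)c(C)nn1C` has not yet been measured. It differs from compound 2 in one place: 2-methylphenyl in place of 3-bromophenyl on an oxygen on an aromatic ring. Among the measured compounds shown here, the only measured step that bears on this position is a 4.5-fold lower number from compound 1 to compound 2 (0.65 log units; beyond the scatter), a modest gain from exchanging one ring on that same oxygen for another. For the measured compounds named here, that step shows the position can move the number, but it exchanged a fluorinated ring for a brominated one, whereas here a methyl-bearing ring enters, and no measured compound carries such a ring at this place. A step of modest size in either direction in this assay is therefore possible, and a small loss is expected. The estimate for compound 3 is 8000 nM, within 2500 nM to 25000 nM, which means an expected step of a 1.6-fold higher number from compound 2 to compound 3 (0.20 log units; within the scatter).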

Compound 3, half-maximal inhibitory concentration: 5120 nM
Compound 3: middle estimate off by 1.6-fold (0.19 log units), on the high side; the range from low to high includes it.
By their numbers in this assay, from the lowest: compounds 2 and 3 (each within the scatter of the next); then compound 1.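

In this assay the 2-methylphenyl ring on this oxygen and the 3-bromophenyl ring give matching results, with a 1.0-fold higher number from compound 2 to compound 3 (0.00 log units; within the scatter), so a bromine on that ring is not needed to reach this level. Against the 2,3-difluorophenyl ring, the 2-methylphenyl ring shows a 4.5-fold lower number from compound 1 to compound 3 (0.65 log units; beyond the scatter), a step of the same size as the one seen with bromine, which sets compound 1 apart from the other two compounds. Nothing measured here accounts for these numbers.

The three rings differ in both the kind of group they carry and where it sits, so these compounds cannot separate the two effects. A plain phenyl ring, a 3-methylphenyl ring and a ring bearing an amine or a carboxylic acid would each test this position further.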